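Cyano in Place of Methoxy: Expected Effect on Binding

This account rests on a few compounds, and the source may have more. Where it says the series, first, only, none or still open, it means among the compounds named here.

Compound 2 `COc1cccc(-c2nc(N)c3nc(-c4ccco4)sc3n2)c1` carries a methoxy group on an aromatic carbon of the shared core. Within the data shown here, in an assay on CHO cells for displacement of a labelled ligand from adenosine receptor A1 (Homo sapiens), read by scintillation counting, with a stated time of 3 h (a higher number here means a weaker inhibitor, a lower number a stronger inhibitor), compound 2 gives 62.3 nM, the higher of the two numbers measured so far. Among the measured compounds shown here, its only measured neighbour, compound 1 `Nc1nc(-c2cccc(CO)c2)nc2sc(-c3ccco3)nc12`, gives 28 nM in this assay, and the step of a 2.2-fold higher number from compound 1 to compound 2 (0.35 log units; beyond the scatter) shows that exchanging hydroxymethyl for methoxy weakened binding modestly. The step from compound 2 to compound 3 `N#Cc1cccc(-c2nc(N)c3nc(-c4ccco4)sc3n2)c1` is cyano in place of methoxy on an aromatic carbon. For the measured compounds named here, no measured step involves a cyano group, so the only guide is the step from compound 1 to compound 2, which indicates that exchanging one small substituent for another on the same aromatic carbon moves the number modestly rather than strongly. The direction for compound 3 is uncertain because a 2.2-fold higher number from compound 1 to compound 2 (0.35 log units; beyond the scatter) concerned a different pair of groups. Compound 3 is therefore expected to show only a small step, a 1.2-fold lower number from compound 2 to compound 3 (0.10 log units; within the scatter). The estimate for compound 3 in this assay is 50 nM, within a range from 20 nM to 130 nM.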

Compound 3, inhibition constant: 103 nM
For compound 3 the middle estimate is 2.1-fold (0.31 log units) below the measured one; low and high end bracket the measured number.
By their numbers in this assay, from the lowest: compound 1; then compounds 2 and 3 (each within the scatter of the next).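

In this assay, cyano in place of methoxy on an aromatic carbon, meta to a large group, gives a 1.7-fold higher number from compound 2 to compound 3 (0.22 log units; within the scatter) and so does not separate these two groups at this position. Cyano in place of hydroxymethyl gives a 3.7-fold higher number from compound 1 to compound 3 (0.57 log units; beyond the scatter) and, taken with a 2.2-fold higher number from compound 1 to compound 2 (0.35 log units; beyond the scatter) as well, this sets compound 1 apart: among these three compounds, only the one carrying hydroxymethyl stands clear of the others, with the lowest number, while compound 2 and compound 3 remain level within the scatter. No measurement available here bears on the reason for this outcome.

The compounds shown leave open whether the lower number of compound 1 belongs to hydroxymethyl alone or would also be seen with an amine, a carboxylic acid or a longer chain ending in a hydroxyl group on the same aromatic carbon. They also leave open whether hydroxymethyl would still stand apart from methoxy and cyano if these groups sat on another carbon of that ring or if another part of the shared core were changed.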